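Notes on the amide substituent step from compound 2 to compound 3

The source may hold more compounds than are shown below. What is called first, only, known or untested is meant among the compounds shown, and "the series" means these compounds.

Compound 2 `O=C(Nc1cccc(-c2oc3cc(-c4ccc(F)cc4)ccc3c(=O)c2O)c1)c1ccc([N+](=O)[O-])cc1` gives 14700 nM in a functional assay on MDA-MB-231 cells (Homo sapiens) for antiproliferative activity, read by CCK-8 assay, with a stated time of 72 h (a lower number here means a stronger inhibitor, a higher number a weaker inhibitor), the lower of the two numbers in hand. Among the measured compounds shown here, its only neighbour, compound 1 `O=C(Nc1cccc(-c2oc3cc(-c4ccc(F)cc4)ccc3c(=O)c2O)c1)c1ccc(C(F)(F)F)cc1`, gives 29400 nM in this assay, and the single measured step, a 2.0-fold lower number from compound 1 to compound 2 (0.30 log units; within the scatter), lies within the scatter. Compound 3 `O=C(Nc1cccc(-c2oc3cc(-c4ccc(F)cc4)ccc3c(=O)c2O)c1)c1ccc(-c2ccccc2)cc1` differs from compound 2 by phenyl in place of nitro on an aromatic carbon, or, cut one bond further out, 4-nitrophenyl to 4-phenylphenyl. For the measured compounds named here, no measured step exchanges the nitro for a ring; the one step known, a 2.0-fold lower number from compound 1 to compound 2 (0.30 log units; within the scatter), shows only that changing the group on this aromatic carbon from trifluoromethyl to nitro left this assay within the scatter. On that basis no step beyond the scatter is expected in this assay, in either direction. Compound 3 is therefore estimated at 15000 nM, with a range of 5000 nM to 45000 nM. The expected step is a 1.0-fold higher number from compound 2 to compound 3 (0.01 log units; within the scatter), inside the scatter.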

Compound 3, half-maximal inhibitory concentration: 63200 nM
Compound 3: the middle estimate sits 4.2-fold (0.62 log units) below what was measured; measured number above the stated range.
By their numbers in this assay, from the lowest: compounds 2 and 1 (each within the scatter of the next); then compound 3.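

The group on this aromatic carbon does register in this assay once a ring enters: phenyl in place of nitro gives a 4.3-fold higher number from compound 2 to compound 3 (0.63 log units; beyond the scatter) and phenyl in place of trifluoromethyl gives a 2.1-fold higher number from compound 1 to compound 3 (0.33 log units; beyond the scatter) with both steps beyond the scatter, whereas the earlier exchange of trifluoromethyl for nitro stayed within it. Among the three groups compared here, the position therefore separates phenyl from the other two, and compound 3 carries the highest number of the set. No measurement on hand gives a reason for this step.

Whether the rise follows the aromatic ring itself or simply the larger count of heavy atoms stays open, since phenyl is the only ring group shown. A saturated cyclohexyl ring, an amine or a carboxylic acid on this carbon would help separate these readings.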